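The compounds below may be only part of what the source reports. "The series", "measured", "known", "first", "only" and "open" are said of these compounds alone.

Of the compounds shown here, two have been read so far in a functional assay on HL-60 cells (Homo sapiens) for antiproliferative activity, read by MTT assay, with a stated time of 72 h; a lower number here means a stronger inhibitor, a higher number a weaker inhibitor. Compound 1 (`CCCCOC(=O)N1CCN(/[N+]([O-])=N/Oc2cc(O/N=[N+](\[O-])N(C)C)c([N+](=O)[O-])cc2[N+](=O)[O-])CC1`) gives 900 nM, and compound 2 (`CCN(CC)C(=O)N1CCN(/[N+]([O-])=N/Oc2cc(O/N=[N+](\[O-])N(C)C)c([N+](=O)[O-])cc2[N+](=O)[O-])CC1`) gives 1900 nM, the higher of the two numbers. Compound 3 (`CCN(CC)C(=O)N1CCN(/[N+]([O-])=N/Oc2cc(O/N=[N+](\[O-])N(CC)CC)c([N+](=O)[O-])cc2[N+](=O)[O-])CC1`) differs from compound 2 at one place: diethylamino in place of dimethylamino on a double-bonded nitrogen. In words, this is diethylamino in place of dimethylamino on a double-bonded nitrogen. Among the measured compounds shown here, the only measured step is a 2.1-fold higher number from compound 1 to compound 2 (0.32 log units; beyond the scatter), a modest one for diethylamino in place of butoxy on a carbonyl carbon. For the measured compounds named here, that step lies at another place in the structure and bears only loosely on this change, and no measured step covers the new site. No shift beyond the scatter is therefore expected in this assay, and the expected step is a 1.1-fold lower number from compound 2 to compound 3 (0.02 log units; within the scatter). For compound 3 the estimated value is 1800 nM, with an expected range from 700 nM to 4500 nM.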

Compound 3, half-maximal inhibitory concentration: 2900 nM
The estimate for compound 3 lay 1.6-fold (0.21 log units) below the measured number, within the range that was stated.
By their numbers in this assay, from the lowest: compound 1; then compounds 2 and 3 (each within the scatter of the next).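

In this assay, the first step read at this site, on a double-bonded nitrogen whose other neighbours are double-bonded nitrogen and oxygen, is a 1.5-fold higher number from compound 2 to compound 3 (0.18 log units; within the scatter) for diethylamino in place of dimethylamino. With the diethylamino group on the carbonyl carbon held constant, going from 3 to 5 heavy atoms in this group therefore gives no shift beyond the scatter, so this site accepts the larger of the two dialkylamino groups in this assay. No measurement at hand gives a cause for this step. 

Going by these compounds, it remains open whether the same exchange reads alike when the butoxy group of compound 1 stands on the carbonyl carbon. Also open, on these data alone, is whether dipropylamino or a ring amine such as morpholine at this site would give a step beyond the scatter.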